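The compounds below may be only part of what the source reports. "The series", "measured", "known", "first", "only" and "open" are said of these compounds alone.

Compound 1: `CCCCCc1ccc(-c2cc3cn([C@H]4C[C@H](O)[C@@H](COC(=O)[C@@H](NC(=O)[C@@H]5CCCN5C(=O)[C@@H](N)C(C)C)C(C)C)O4)c(=O)nc3o2)cc1`, which in an ADME assay on HEL cells (Homo sapiens) for inhibition (on this read-out lower numbers stand for higher toxicity in this test and higher numbers for lower toxicity in this test), gives a limit of > 100000 nM.
Compound 2: `CCCCCc1ccc(-c2cc3cn([C@H]4C[C@H](OC(=O)[C@@H](NC(=O)[C@@H]5CCCN5C(=O)[C@@H](N)C(C)C)C(C)C)[C@@H](CO)O4)c(=O)nc3o2)cc1`, 17000 nM.
Compound 3: `CCCCCc1ccc(-c2cc3cn([C@H]4C[C@H](O)[C@@H](COC(=O)[C@H](C)NC(=O)[C@@H]5CCCN5C(=O)[C@@H](N)C(C)C)O4)c(=O)nc3o2)cc1`, 44000 nM.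

Compound 1 stands only at a limit of this assay, (the limit of > 100000 nM in this assay, at which 1 of the 3 values shown sits), so no number fixes its place among the measured compounds. Within the data shown here, the single measured step, an at least 2.2-fold lower number from compound 1 to compound 3 (0.35 log units; beyond the scatter), concerns another place in the molecule than the change followed here. Compound 4, `CCCCCc1ccc(-c2cc3cn([C@H]4C[C@H](O)[C@@H](COC(=O)[C@@H](NC(=O)[C@@H]5CCCN5C(=O)[C@@H](N)CCCCN)C(C)C)O4)c(=O)nc3o2)cc1`, differs from compound 1 by 4-aminobutyl in place of isopropyl on a saturated chain carbon bound to an amine nitrogen and a carbonyl carbon. Among the measured compounds shown here, no measured step bears on this change, so no step beyond the scatter is foreseen in either direction. Near compound 1 is where compound 4 is expected, with an estimate of 100000 nM (range 30000 nM to 300000 nM), which would mean a number no higher from compound 1 to compound 4 (the limit leaves the size open); a limit is again considered likely.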

Compound 4, half-maximal cytotoxic concentration in the HEL assay: 29000 nM
Compound 4: middle estimate off by 3.4-fold (0.54 log units), on the high side, and the stated range ends above it.
By their numbers in the HEL assay, from the lowest: compounds 2, 4 and 3 (each within the scatter of the next, the first and the last beyond it). At a limit, above all of these: compound 1.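

Among these compounds, in the HEL assay, 4-aminobutyl in place of isopropyl on a saturated chain carbon bound to an amine nitrogen and a carbonyl carbon gives an at least 3.4-fold lower number from compound 1 to compound 4 (0.53 log units; beyond the scatter), so this position, which no earlier step covered, does bear on the read-out. Among the compounds shown here, only one end of that step is a number, as compound 1 stands at a limit: the limit of > 100000 nM in the HEL assay, at which 1 of the 4 values shown sits. In a physicochemical assay for solubility, with a stated time of 24 h (a higher number here means a more soluble compound, a lower number a less soluble compound), compound 1 gives 1200 ug/mL and compound 4 gives 55000 ug/mL. The same change also bears on solubility: the measured solubility of compound 1, 1200 ug/mL, and of compound 4, 55000 ug/mL, a 46-fold higher number (1.66 log units; beyond the scatter).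

The compounds shown do not separate the amine of 4-aminobutyl from its longer chain. A plain butyl chain or a carboxylic acid on the same carbon would speak to that.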